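A few compounds are considered here, and "the series" means these few. Any claim that something is new, unique, unknown or untested is made for them only; others in the source may bear on it.

Compound 3, with structure `CCC(C)C(NC(=O)c1ccc(C(CC)(CC)c2ccc(OCCC(O)(CC)CC)c(C)c2)n1CC)C(=O)OC`, stands at the edge of what a functional assay on HepG2 cells (Homo sapiens) for antiproliferative activity, read by MTT assay, with a stated time of 48 h (on this read-out lower numbers stand for stronger inhibition and higher numbers for weaker inhibition), can report: in this assay compound 3 gives > 50000 nM, which is a limit rather than a number. Its two neighbours are no different in kind. Compound 1, `C#CCCOC(=O)c1ccc(C(CC)(CC)c2ccc(OCCC(O)(CC)CC)c(C)c2)n1CC`, gives in this assay > 50000 nM, again a limit. Compound 2, `CCn1c(C(=O)Nc2cccc(C(F)(F)F)c2)ccc1C(CC)(CC)c1ccc(OCCC(O)(CC)CC)c(C)c1`, gives in this assay > 50000 nM, also a limit. Because all three sit at the limit of > 50000 nM in this assay, at which 3 of the 3 values shown sit, every step among them is unreadable: a step that the two limits leave unreadable from compound 1 to compound 3, and a step that the two limits leave unreadable from compound 2 to compound 3, and likewise a step that the two limits leave unreadable from compound 1 to compound 2.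

Compound 4, `CCn1c(C(=O)NC(CO)CCO)ccc1C(CC)(CC)c1ccc(OCCC(O)(CC)CC)c(C)c1`, differs from compound 3 at the amide-type nitrogen: a group of 6 heavy atoms (4 carbon, 2 oxygen; no ring) in place of a group of 9 heavy atoms (7 carbon, 2 oxygen; no ring), on an amide-type nitrogen. The two measured steps that touch the same position, from compound 1 to compound 3 and from compound 2 to compound 3, both run between limits and therefore give no readable size, so there is no measured basis for any movement in this assay, up or down.

Given that every comparable change so far has left the read-out at its limit, compound 4 is expected to remain there as well, with an estimated value of 80000 nM, within a range from 20000 nM to 300000 nM, and an expected step that the limit leaves unreadable from compound 3 to compound 4 from compound 3 to compound 4.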

Compound 4, half-maximal inhibitory concentration: 24800 nM
The estimate for compound 4 lay 3.2-fold (0.51 log units) above the measured number; the measured number falls inside the stated range.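

In this assay, compound 4 is the first of the compounds shown to give a number rather than a limit, and this gives the steps to it a direction: 3-hydroxy-1-(hydroxymethyl)propyl on the amide-type nitrogen gives an at least 2.0-fold lower number from compound 3 to compound 4 (0.30 log units; that floor lies within the scatter), the same group in place of 3-(trifluoromethyl)phenyl gives an at least 2.0-fold lower number from compound 2 to compound 4 (0.30 log units; that floor lies within the scatter), and the change on the carbonyl carbon gives an at least 2.0-fold lower number from compound 1 to compound 4 (0.30 log units; that floor lies within the scatter). Going by these compounds, each of these is only a floor, and each floor lies within the scatter, so the true size of the steps remains unknown. Even so, the position is no longer known only from values at the limit, and the one group shown here to leave that limit carries 2 hydrogen-bond donors, against 0 in the group it replaces from compound 3: the limit of > 50000 nM in this assay, at which 3 of the 4 values shown sit.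

The compounds shown leave open whether a single hydroxyl, an amine or a carboxylic acid on a chain at this nitrogen would move the number further or return it to the limit. They also cannot separate the hydroxyl groups from the change in size, as the group in compound 4 differs from that in compound 3 in both at once.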